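Chloromethyl for vinyl on two related amide cores

A few compounds are considered here, and "the series" means these few. Any claim that something is new, unique, unknown or untested is made for them only; others in the source may bear on it.

The compounds were tested in a functional assay on Maver1 cells (Homo sapiens) for inhibition, read by luminescence and CellTiter-Glo, with a stated time of 72 h; on this read-out lower numbers stand for stronger inhibition and higher numbers for weaker inhibition. Compound 1 `C=CC(=O)Nc1ccc(Cn2nc(-c3ccc(Oc4ccccc4)cc3)cc2C(=O)O)cc1` reaches only the limit of this assay, at > 60000 nM. Compound 2 `O=C(CCl)Nc1ccc(Cn2nc(-c3ccc(Oc4ccccc4)cc3)cc2C(=O)O)cc1` gives 1200 nM in this assay. The difference between them is chloromethyl in place of vinyl on a carbonyl carbon, and the step is an at least 50-fold lower number from compound 1 to compound 2 (1.69 log units; beyond the scatter); that step is read against (the limit of > 60000 nM in this assay, at which 2 of the 3 values shown sit), so its true size is not known. Compound 3 `C=CC(=O)N1CCCC(n2nc(-c3ccc(Oc4ccccc4)cc3)cc2C(=O)OCC)C1` also sits at the limit in this assay, at > 60000 nM. How the core of compound 3 differs from the core of compound 1 is not broken down here. Compound 4 `CCOC(=O)c1cc(-c2ccc(Oc3ccccc3)cc2)nn1C1CCCN(C(=O)CCl)C1` is not yet measured; it differs from compound 3 by chloromethyl in place of vinyl on a carbonyl carbon. This is the same kind of change as that from compound 1 to compound 2, but the place differs: here the carbonyl carbon's other neighbour is an amide-type nitrogen in a ring, whereas in compound 1 it is an amide-type nitrogen. Because compound 2 gives 1200 nM after this change, a lowering is expected for compound 4 as well, namely an at least 7.5-fold lower number from compound 3 to compound 4 (0.87 log units; beyond the scatter), though a smaller one than the earlier step is expected since the cores differ. Compound 4 is therefore estimated at 8000 nM, between 1500 nM and 60000 nM.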

Compound 4, half-maximal inhibitory concentration: 1200 nM
Beside the measured number, compound 4's estimate is 6.7-fold (0.82 log units) above it; measured number below the stated range.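

In this assay, chloromethyl in place of vinyl on the carbonyl carbon again goes with a large change, here on the core with an amide-type nitrogen in a ring: an at least 50-fold lower number from compound 3 to compound 4 (1.69 log units; beyond the scatter). Set beside the earlier step, the change points the same way on both cores, so in these two pairs its direction carries over from one core to the other: the same change on two cores in this assay, an at least 50-fold lower number (1.69 log units; beyond the scatter) from compound 1 to compound 2 and an at least 50-fold lower number (1.69 log units; beyond the scatter) from compound 3 to compound 4; the limit leaves it open whether they differ. What this does not show is that the size of the change carries over, for each step starts from a vinyl compound that rests on a limit: the limit of > 60000 nM in this assay, at which 2 of the 4 values shown sit.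

The compounds shown leave open how a group other than chloromethyl would read on the same carbonyl carbon, such as bromomethyl or a longer chain. They also leave open what the rest of each core contributes, including the carboxylic acid of compound 1 and compound 2, as no two compounds shown differ in that place alone.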